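The source may report more compounds than this note shows. Statements on the series, on what has been measured and on what is new or still open speak of the compounds shown alone.

Measured so far in an assay on isolated protein for inhibition of serine/threonine-protein kinase PAK 1 (Homo sapiens), read by ADP-Glo, with a stated time of 40 min; on this read-out lower numbers stand for stronger inhibition and higher numbers for weaker inhibition:

compound 1, `Cc1ccccc1C(=O)NC1CCN(c2ncnc3[nH]ncc23)CC1` — 6260 nM
compound 2, `COc1ccc(NC(=O)NC2CCN(c3ncnc4[nH]ncc34)CC2)cc1` — 6370 nM

Within the data shown here, compound 2 gives the higher of the two numbers, but its only neighbour is compound 1, and the step of a 1.0-fold higher number from compound 1 to compound 2 (0.01 log units; within the scatter) sits within the scatter, so the two compounds are not distinguished on the numbers in hand.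

Compound 3, `O=C(Nc1cccc(Cl)c1)NC1CCN(c2ncnc3[nH]ncc23)CC1`, has not been measured. Relative to compound 2 the change is 3-chlorophenyl in place of 4-methoxyphenyl on an amide-type nitrogen. Among the measured compounds shown here, the one measured step, from compound 1 to compound 2, also altered the aryl group carried on the carbonyl side of the shared core, together with the linking atom, and it produced no movement beyond the scatter. For the measured compounds named here, that is the only evidence bearing on the new step; it is a single step and the change to compound 3 touches the aryl group alone, so it speaks only loosely.

On that basis the number for compound 3 is expected to stay close to that of compound 2, with a step of a 1.1-fold lower number from compound 2 to compound 3 (0.03 log units; within the scatter) not beyond the scatter. Compound 3 is therefore estimated at 6000 nM, in the range 2500 nM to 15000 nM.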

Compound 3, half-maximal inhibitory concentration: 1240 nM
Compound 3: the middle estimate sits 4.8-fold (0.68 log units) above what was measured, outside the stated range (below it).
By their numbers in this assay, from the lowest: compound 3; then compounds 1 and 2 (each within the scatter of the next).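

In this assay the aryl group on the amide-type nitrogen proves able to move the number: 3-chlorophenyl in place of 4-methoxyphenyl gives a 5.1-fold lower number from compound 2 to compound 3 (0.71 log units; beyond the scatter) and so separates two compounds at this position, which the earlier pair of compounds had not done. The change from the other measured compound, (3-chlorophenyl)amino in place of 2-methylphenyl on a carbonyl carbon, gives a 5.0-fold lower number from compound 1 to compound 3 (0.70 log units; beyond the scatter) and points the same way, leaving compound 3 as the only one of the three set apart, while compounds 1 and 2 stay within the scatter of each other. No measurement at hand accounts for this lower number.

Going by these compounds, how a plain phenyl, or an aryl ring carrying fluorine, trifluoromethyl or a nitrile, would read at this position stays open, so the step cannot yet be assigned to the chlorine itself or to the loss of the methoxy group. Also open, on these data alone, is whether an amine or a carboxylic acid on the ring, or a longer chain in place of the aryl group, would take the number lower still.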